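Benzyl on the aniline nitrogen across two cores

The source may report more compounds than this note shows. Statements on the series, on what has been measured and on what is new or still open speak of the compounds shown alone.

Measured so far, all in a functional assay on HT-29 cells (Homo sapiens) for antiproliferative activity, read by MTT assay, with a stated time of 72 h; a higher number here means a weaker inhibitor of growth, a lower number a stronger inhibitor of growth:
compound 1 `COc1cc(OC)n2cc(-c3ccc(N)cc3)nc2n1` with > 100000 nM, a limit of the assay;
compound 2 `COc1cc(OC)n2cc(-c3ccc(NCc4ccccc4)cc3)nc2n1` with > 100000 nM, likewise a limit;
compound 3 `Cc1ccn2cc(-c3ccc(N)cc3)nc2c1` with 93600 nM, the one real number in the set.

Compound 1 and compound 2 differ by benzyl in place of hydrogen on a nitrogen on an aromatic ring. Both values sit at the limit, so the step that the two limits leave unreadable from compound 1 to compound 2 cannot be read, a point that rests on (the limit of > 100000 nM in this assay, at which 2 of the 3 values shown sit). Compound 3 carries a different core; the difference between the two cores is not broken down here, and its value shows only weak inhibition.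

Compound 4 `Cc1ccn2cc(-c3ccc(NCc4ccccc4)cc3)nc2c1` has not yet been measured. It differs from compound 3 by benzyl in place of hydrogen on a nitrogen on an aromatic ring, the same change that leads from compound 1 to compound 2, made at a place described in the same words. Since that earlier step is unreadable and compound 3 is itself near the limit, the expected step from compound 3 to compound 4 in this assay is estimated as a 1.1-fold higher number from compound 3 to compound 4 (0.03 log units; within the scatter), carrying much uncertainty. Compound 4 is expected to give about 100000 nM, estimated between 30000 nM and 300000 nM.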

Compound 4, concentration for 50% growth inhibition: 17500 nM
For compound 4 the middle estimate is 5.7-fold (0.76 log units) above the measured one; measured number below the stated range.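

In this assay, putting benzyl in place of hydrogen on a nitrogen on an aromatic ring gives a 5.3-fold lower number from compound 3 to compound 4 (0.73 log units; beyond the scatter) and so, on this core, the change goes with stronger inhibition of growth. On the core of compound 1 the same change gives no comparison, since compound 1 and compound 2 both sit at a limit of the assay, so the step between them cannot be read. The gain is therefore seen on one core only, and whether it carries over from one core to the other stays unknown, because the limit hides any step on the core of compound 1: the limit of > 100000 nM in this assay, at which 2 of the 4 values shown sit.

The compounds shown leave open whether a longer chain such as phenylethyl in place of benzyl, or an amine or a carboxylic acid added to the benzyl ring, would lower the number further on the core of compound 3. They also leave open whether the benzyl change would give a readable step on any third core.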